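Diaryl thiourea series: cytotoxicity notes on the amide terminus

A few compounds are considered here, and "the series" means these few. Any claim that something is new, unique, unknown or untested is made for them only; others in the source may bear on it.

Measured so far in a functional assay on PC-3 cells (Homo sapiens) for cytotoxicity, read by MTT assay, with a stated time of 48 h; on this read-out higher numbers stand for weaker inhibition and lower numbers for stronger inhibition:
Compound 1 `CNC(=O)c1cc(Oc2cccc(NC(=S)Nc3ccc(Cl)cc3Cl)c2)ccn1` gives 37800 nM.
Compound 2 `CNC(=O)c1cc(Oc2cccc(NC(=S)Nc3ccc(Cl)cc3)c2)ccn1` gives 24100 nM.
Compound 3 `CNC(=O)c1cc(Oc2cccc(NC(=S)Nc3cccc(C(F)(F)F)c3)c2)ccn1` gives 24500 nM.

Compound 3 stands second highest of the three numbers in this assay; the gap a 1.0-fold higher number from compound 2 to compound 3 (0.01 log units; within the scatter) and the gap a 1.5-fold lower number from compound 1 to compound 3 (0.19 log units; within the scatter) both lie within the scatter, so the three compounds are not separable here.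

Compound 4 `O=C(c1cc(Oc2cccc(NC(=S)Nc3cccc(C(F)(F)F)c3)c2)ccn1)N1CCCC1` differs from compound 3 by pyrrolidin-1-yl in place of methylamino on a carbonyl carbon. Within the data shown here, all three measured steps alter the terminal aryl ring on the thiourea, and none touches the carbonyl end, so no measured step bears on this change. Since those steps, a 1.6-fold lower number from compound 1 to compound 2 (0.20 log units; within the scatter), a 1.5-fold lower number from compound 1 to compound 3 (0.19 log units; within the scatter) and a 1.0-fold higher number from compound 2 to compound 3 (0.01 log units; within the scatter), all stayed within the scatter, no step beyond the scatter is expected for a 1.0-fold higher number from compound 3 to compound 4 (0.01 log units; within the scatter) in either direction.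

Compound 4 is therefore estimated at 25000 nM in this assay, with a range from 9000 nM to 70000 nM.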

Compound 4, half-maximal inhibitory concentration: 27000 nM
Compound 4: the middle estimate sits 1.1-fold (0.03 log units) below what was measured, and the stated range covers the measured number.
By their numbers in this assay, from the lowest: compounds 2, 3, 4 and 1 (each within the scatter of the next).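

Pyrrolidin-1-yl in place of methylamino on a carbonyl carbon is the first change at this end of the series, and in this assay it gives a 1.1-fold higher number from compound 3 to compound 4 (0.04 log units; within the scatter) with the 3-(trifluoromethyl)phenyl group held fixed. In this pair, losing the amide hydrogen and adding a five-membered ring does not move the number beyond the scatter. No measurement at hand offers an explanation for this result.

As far as these compounds go, whether a carboxylic acid or a longer chain on this carbonyl carbon would move the number beyond the scatter stays open. Also open, from the compounds shown here alone, is whether the pyrrolidin-1-yl result carries over to the 4-chlorophenyl and 2,4-dichlorophenyl compounds.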